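Triazole Aryl Swap in an Antiproliferative Series

A few compounds are considered here, and "the series" means these few. Any claim that something is new, unique, unknown or untested is made for them only; others in the source may bear on it.

Compound 1 `Cc1ccc(-n2nncc2CN2C(=O)C3(C(C#N)=C(N)Oc4c3c3nc5ccccc5nc3c3ccccc43)c3ccccc32)cc1Cl`: in an ADME assay on HUVEC cells (Homo sapiens) for antiproliferative activity, read by MTT assay, with a stated time of 48 h (on this read-out higher numbers stand for weaker inhibition and lower numbers for stronger inhibition), compound 1 reaches only the assay limit, > 50000 nM.
Compound 2 `N#CC1=C(N)Oc2c(N)cc3nc4ccccc4nc3c2C12C(=O)N(Cc1cnnn1-c1cccc(Br)c1)c1ccccc12`: in this assay compound 2 reaches only the assay limit, > 50000 nM.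
Compound 3 `COc1ccccc1-n1nncc1CN1C(=O)C2(C(C#N)=C(N)Oc3c(N)cc4nc5ccccc5nc4c32)c2ccccc21`: in this assay compound 3 reaches only the assay limit, > 50000 nM.

Compound 3 therefore stands at the limit of this assay, with no number of its own; the two other compounds stand at the same limit. Going by the values given here, the one step between measured neighbours, a step that the two limits leave unreadable from compound 2 to compound 3, cannot be read because both ends are limits. Compound 4 `N#CC1=C(N)Oc2c(N)cc3nc4ccccc4nc3c2C12C(=O)N(Cc1cnnn1-c1ccc(Cl)cc1Cl)c1ccccc12` differs from compound 3 in one place: 2,4-dichlorophenyl in place of 2-methoxyphenyl on an aromatic nitrogen. Among the compounds with values here, no measured step bears readably on this change, since the limit of > 50000 nM in this assay, at which 3 of the 3 values shown sit, covers every value in the set, and so no movement beyond the scatter is expected in either direction. Compound 4 is expected to give 70000 nM in this assay, within 40000 nM to 200000 nM. The expected step this implies, a step that the limit leaves unreadable from compound 3 to compound 4, is estimated to stay within the scatter, and most likely compound 4 again returns only the limit.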

Compound 4, half-maximal inhibitory concentration: > 50000 nM
Compound 4: only a limit was reported; the forecaster's own chance of this, stated with the estimate: 85%; the middle value lies beyond the limit too.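

No new step can be read between compound 4 and either compound 2 or compound 3, since both ends of each pair are limits in this assay: the limit of > 50000 nM in this assay, at which 4 of the 4 values shown sit.
The compounds shown leave open whether the aryl group on this aromatic nitrogen affects the read-out at all, with none of them giving a number of its own.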